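Fluoro for trifluoromethyl: a second instance in the series

A few compounds are considered here, and "the series" means these few. Any claim that something is new, unique, unknown or untested is made for them only; others in the source may bear on it.

Compound 1 `CNC(=O)c1ccc(Sc2cccc(NC(=S)Nc3ccc(F)c(C(F)(F)F)c3)c2)nc1` and compound 2 `CNC(=O)c1ccc(Sc2cccc(NC(=S)Nc3ccc(F)c(F)c3)c2)nc1` share one core, while compound 3 `CNC(=O)c1ccc(Sc2ccc(NC(=S)Nc3ccc(F)c(C(F)(F)F)c3)cc2)nc1` and compound 4 `CNC(=O)c1ccc(Sc2ccc(NC(=S)Nc3ccc(F)c(F)c3)cc2)nc1` share another. The difference between the two cores is not broken down here. In a functional assay on HCT-116 cells (Homo sapiens) for cytotoxicity, read by MTT assay, with a stated time of 48 h (on this read-out higher numbers stand for weaker inhibition and lower numbers for stronger inhibition), compound 1 gives 18200 nM and compound 2 gives 35100 nM. The change between them is fluoro in place of trifluoromethyl on an aromatic carbon, and it gives a 1.9-fold higher number from compound 1 to compound 2 (0.29 log units; within the scatter). In this assay compound 3 gives 6370 nM, the lowest of the three numbers. The change from compound 3 to compound 4 is fluoro in place of trifluoromethyl on an aromatic carbon, the same change at the same place as before. Among the measured compounds shown here, for compound 4 the expected step is a 1.9-fold higher number from compound 3 to compound 4 (0.28 log units; within the scatter), resting on the single earlier instance a 1.9-fold higher number from compound 1 to compound 2 (0.29 log units; within the scatter) carried over to compound 3. Compound 4 is therefore expected at 12000 nM. The expected range for compound 4 runs from 5000 nM to 30000 nM, kept wide on a single earlier instance.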

Compound 4, half-maximal inhibitory concentration: 22200 nM
Compound 4: middle estimate off by 1.9-fold (0.27 log units), on the low side; the measured number falls inside the stated range.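

In this assay, putting fluoro in place of trifluoromethyl on the core of compound 3 gives a 3.5-fold higher number from compound 3 to compound 4 (0.54 log units; beyond the scatter). The two instances of this change do not differ by more than the scatter allows: the same change on two cores in this assay, a 1.9-fold higher number (0.29 log units; within the scatter) from compound 1 to compound 2 and a 3.5-fold higher number (0.54 log units; beyond the scatter) from compound 3 to compound 4, 1.8-fold (0.26 log units) apart, within the scatter of two such steps. Among the compounds shown here, the size of the step therefore carries acceptably between these two cores, but two pairs set no rule for other cores, and only the step on the core of compound 3 stands clear of the scatter.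

The compounds shown leave open how a chloro, a methyl, a nitrile or an amine would compare with fluoro and trifluoromethyl at this place. They also leave open whether the step holds on any further core.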